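Swapping the Aryl Group on a Poorly Soluble Core

A few compounds are considered here, and "the series" means these few. Any claim that something is new, unique, unknown or untested is made for them only; others in the source may bear on it.

Going by the values given here, compound 2 `Cc1cc(NCc2ccccn2)n2ncc(-c3ccc(N(C)C)cc3)c2n1` is one of three compounds measured in a physicochemical assay for solubility, read by HPLC, using the shake flask method, measured as kinetic solubility, with a stated time of 2 h, at pH 7.4; a lower number here means a less soluble compound, a higher number a more soluble compound. For compound 2 the result is a limit of the assay, < 5000 nM, not a number. Compound 3 `Cc1cc(NCc2ccccn2)n2ncc(-c3ccc(C(=O)Nc4ccccc4)cc3)c2n1` differs from compound 2 by phenylcarbamoyl in place of dimethylamino on an aromatic carbon, and in this assay compound 3 gives 5000 nM. That change gave a number no lower from compound 2 to compound 3 (the limit leaves the size open). Compound 1 `Cc1cc(NCc2cccnc2)n2nc(C)c(-c3ccccc3)c2n1`, built on a different core, gives 110000 nM in this assay. Compound 4 `Cc1cc(NCc2ccccn2)n2ncc(-c3ccc(F)cc3C)c2n1` has not been measured; it differs from compound 2 by 4-fluoro-2-methylphenyl in place of 4-(dimethylamino)phenyl on an aromatic carbon. Among the compounds with values here, no measured step mirrors this change, and the only step that starts at compound 2 begins from a limit (the limit of < 5000 nM in this assay, at which 1 of the 3 values shown sits), so its size cannot be read. With nothing pointing either way, compound 4 is expected to stay close to where compound 2 sits, with no movement beyond the scatter foreseen. For compound 4 the expected step is a number no lower from compound 2 to compound 4 (the limit leaves the size open). Compound 4 is estimated at 5000 nM, between 1500 nM and 20000 nM.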

Compound 4, solubility: 42300 nM
Beside the measured number, compound 4's estimate is 8.5-fold (0.93 log units) below it; the measured number lies above the stated range.
By their numbers in this assay, from the lowest: compound 3; then compound 4; then compound 1.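

At this place on the five-membered aromatic ring, 4-fluoro-2-methylphenyl in place of 4-(dimethylamino)phenyl gives an at least 8.4-fold higher number from compound 2 to compound 4 (0.92 log units; beyond the scatter) in this assay, so swapping this aryl group can move the number by more than the scatter. Going by these compounds alone, the earlier step from compound 2 to compound 3 cannot be read in size, and this is the first step from compound 2 with a readable size. Even so, that size is only a floor, as compound 2 carries a limit of the assay and not a number: the limit of < 5000 nM in this assay, at which 1 of the 4 values shown sits.

Which part of the change goes with the step stays open: the fluoro group, the methyl group or the loss of dimethylamino. Also open, on these data alone, is how a phenyl ring carrying a carboxylic acid or a morpholine at this same place would read in this assay.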